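The compounds below may be only part of what the source reports. "The series", "measured", "known", "first", "only" and "open" are said of these compounds alone.

Compound 1 `C/N=C(\S)n1nc(-c2ccccc2)nc1N`: 54%.
Compound 2 `C/N=C(\S)n1nc(-c2ccc(C)cc2)nc1N`: 65%.

Both numbers come from a functional assay on the whole organism for inhibition, with Rattus norvegicus as the target, at a dose of 30 mg/kg; a lower number here means less inhibition, a higher number more inhibition at the dose given (going by the name of the read-out). Among the compounds with values here, compound 2 stands highest of the two numbers measured; its nearest neighbour is compound 1, and the step of a number 11 percentage points higher from compound 1 to compound 2 (beyond the scatter) is the only measured step that exists. Compound 3 `C/N=C(\S)n1nc(-c2ccc(C#N)cc2)nc1N` is not yet measured. It differs from compound 2 in one place: cyano in place of methyl on an aromatic carbon. Within the data shown here, the single measured step bears on this change only in part: it shows how large the rise was when methyl replaced hydrogen at that aromatic carbon, and it was modest. Among the measured compounds shown here, no measured pair shows cyano in place of methyl, so the direction of the coming step rests on little. Since the earlier step was modest, the group leaving is assumed to give back about what it brought, and the group entering is assumed to add nothing large. The step of a number 10 percentage points lower from compound 2 to compound 3 (within the scatter) is therefore expected to stay within the scatter. The estimate for compound 3 in this assay is 55%, with a range from 35% to 75%.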

Compound 3, a percentage reported as inhibition, in the whole organism at one dose (the size of the read-out at that dose, not a potency): 87%
Beside the measured number, compound 3's estimate is 32 percentage points below it, outside the stated range (above it).
By their numbers in this assay, from the lowest: compound 1; then compound 2; then compound 3.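

In this assay, the aromatic carbon para to a large group does not simply return to the level of hydrogen when methyl leaves: cyano in place of methyl gives a number 22 percentage points higher from compound 2 to compound 3 (beyond the scatter) and so carries the number further up. With hydrogen as the starting point, cyano gives a number 33 percentage points higher from compound 1 to compound 3 (beyond the scatter) in one change, whereas methyl gives a number 11 percentage points higher from compound 1 to compound 2 (beyond the scatter) at the same carbon, so both groups lift the number over hydrogen, cyano by a large step and methyl by a modest one. Nothing at hand accounts for this order of hydrogen, methyl and cyano.

The three compounds leave open whether other groups at this carbon, such as an amine, a carboxylic acid or a longer chain like ethyl, would lift the number further, hold it, or lower it. They also leave open whether cyano gives a similar rise on the other carbons of the ring, and whether the order of these compounds would hold at doses other than the single one reported here.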